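Trifluoromethoxy in place of trifluoromethyl: notes on the series

The source may report more compounds than this note shows. Statements on the series, on what has been measured and on what is new or still open speak of the compounds shown alone.

In an ADME assay on HEK293 cells (Homo sapiens) for cytotoxicity, with a stated time of 72 h (on this read-out higher numbers stand for an effect only at larger amounts of compound and lower numbers for an effect already at smaller amounts), compound 3 `Cc1cc(NC(=O)Nc2ccc(C(F)(F)F)cc2)c2ccccc2n1` gives 25000 nM. Compound 2 `CCc1ccc(NC(=O)Nc2cc(C)nc3ccccc23)cc1` gives 16000 nM, which places compound 3 within the scatter of it, at a 1.6-fold higher number from compound 2 to compound 3 (0.19 log units; within the scatter). Compound 1 `Cc1cc(NC(=O)Nc2ccc(C(C)(C)C)cc2)c2ccccc2n1` gives > 25000 nM, which is a limit of this assay and not a number.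

Compound 4 `Cc1cc(NC(=O)Nc2ccc(OC(F)(F)F)cc2)c2ccccc2n1` carries trifluoromethoxy in place of trifluoromethyl on an aromatic carbon, para to a large group (trifluoromethoxy in place of trifluoromethyl on an aromatic carbon). Among the measured compounds shown here, only three measured steps bear on this change, all exchanges of the same group: an at least 1.5-fold lower number from compound 1 to compound 2 (0.19 log units; that floor lies within the scatter), a number no higher from compound 1 to compound 3 (the limit leaves the size open) and the step from compound 2 already given. Neither readable step lies beyond the scatter, and the series holds no direct measurement of trifluoromethoxy. No step beyond the scatter is therefore expected, and the expected step is a 1.4-fold lower number from compound 3 to compound 4 (0.14 log units; within the scatter). For compound 4 the estimated value is 18000 nM, with an expected range of 9000 nM to 25000 nM. A report as a limit also remains possible, given (the limit of > 25000 nM in this assay, at which 1 of the 3 values shown sits).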

Compound 4, half-maximal effective concentration: 14000 nM
Compound 4: the middle estimate sits 1.3-fold (0.11 log units) above what was measured; the measured number falls inside the stated range.
By their numbers in this assay, from the lowest: compounds 4, 2 and 3 (each within the scatter of the next).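

Trifluoromethoxy in place of trifluoromethyl, para to a large group, brings an oxygen and a hydrogen-bond acceptor to this position, and in this assay the outcome is a 1.8-fold lower number from compound 3 to compound 4 (0.25 log units; within the scatter). The comparison with ethyl gives a 1.1-fold lower number from compound 2 to compound 4 (0.06 log units; within the scatter), so ethyl, trifluoromethyl and trifluoromethoxy, the three groups here with readable numbers, now all lie within the scatter of one another, and this position has yet to show a change beyond it among them. The comparison with tert-butyl gives an at least 1.7-fold lower number from compound 1 to compound 4 (0.25 log units; that floor lies within the scatter), so this step also fails to show a difference beyond the scatter.

As far as these compounds go, how far tert-butyl truly stands from the other groups stays open: the limit of > 25000 nM in this assay, at which 1 of the 4 values shown sits. From the compounds shown here alone, whether an amine, a carboxylic acid or a longer chain at this position would move the number beyond the scatter also stays open.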